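This account rests on a few compounds, and the source may have more. Where it says the series, first, only, none or still open, it means among the compounds named here.

Working notes on the series.

The series shares a core with a primary amine and a thiophene; the variation sits on the amide nitrogen. Compound 1 `C#CCN(CC=C)C(=O)[C@@]1(c2ccsc2)C[C@H]1CN` carries propargyl and allyl there, compound 2 `COCCN(C)C(=O)[C@@]1(c2ccsc2)C[C@H]1CN` methyl and methoxyethyl. In an assay on HEK293 cells for inhibition of sodium-dependent dopamine transporter (Homo sapiens) (on this read-out higher numbers stand for weaker inhibition and lower numbers for stronger inhibition), compound 2 gives only a limit, > 10000 nM, not a number. In this assay compound 1 likewise gives only a limit, > 10000 nM. Both values shown thus sit at the same limit (the limit of > 10000 nM in this assay, at which 2 of the 2 values shown sit), so no ordering between compound 1 and compound 2 can be read from them.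

The unmeasured compound 3 `C#CCN(CCOC)C(=O)[C@@]1(c2ccsc2)C[C@H]1CN` differs from compound 2 by ethynyl in place of hydrogen on a saturated chain carbon bound to an amide-type nitrogen. The expected step from compound 2 to compound 3 is a step that the limit leaves unreadable from compound 2 to compound 3, meaning no move beyond the scatter, since compound 1 with its propargyl group already sits at the limit > 10000 nM. Compound 3 is therefore estimated at 20000 nM, between 5000 nM and 100000 nM, most likely reported again as a limit.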

Compound 3, half-maximal inhibitory concentration: > 10000 nM
Compound 3: a limit, no number; the forecaster's own chance of this, stated with the estimate: 80%; the middle value lies beyond the limit too.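

No step can be read among compound 1, compound 2 and compound 3 in this assay, since all three values are limits, not numbers: the limit of > 10000 nM in this assay, at which 3 of the 3 values shown sit.

The compounds shown leave open how far each lies beyond that limit, and whether any amide nitrogen substituent gives a measurable value in this assay.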